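Removing the trifluoromethyl group from compound 1

The source may hold more compounds than are shown below. What is called first, only, known or untested is meant among the compounds shown, and "the series" means these compounds.

compound 1 `Cn1nc(-c2cccc(C(F)(F)F)c2)n(C)c1=S` gives > 50 mg/kg
compound 2 `Cn1c(S)nnc1-c1ccc(Cl)cc1` gives > 50 mg/kg
compound 3 `Cn1nc(-c2cccc3ccccc23)n(C)c1=S` gives > 50 mg/kg

In a functional assay on the whole organism with Mus musculus as the target (on this read-out lower numbers stand for an effect already at smaller amounts and higher numbers for an effect only at larger amounts of compound), compound 1 gives > 50 mg/kg as a limit and not a number. Among the measured compounds shown here, the series so far offers only the limit of > 50 mg/kg in this assay, at which 3 of the 3 values shown sit, and no measured step. Compound 4 `Cn1nc(-c2ccccc2)n(C)c1=S` carries hydrogen in place of trifluoromethyl on an aromatic carbon. For the measured compounds named here, with no measured step to size this change, a modest shift in this assay towards smaller doses is expected, and another reading at the limit remains quite possible. The estimated step is an at least 1.2-fold lower number from compound 1 to compound 4 (0.09 log units; that floor lies within the scatter) and stays uncertain. Compound 4 is expected near 40 mg/kg (estimated range 15 mg/kg to 100 mg/kg).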

Compound 4, dose for half-maximal effect: 0.15 mg/kg
Compound 4: middle estimate off by 270-fold (2.43 log units), on the high side; the measured number lies below the stated range.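

In this assay, among the compounds shown here, hydrogen in place of trifluoromethyl on an aromatic carbon gives an at least 330-fold lower number from compound 1 to compound 4 (2.52 log units; beyond the scatter), the first measured step and evidence that this position strongly affects the read-out. Compound 1 gives > 50 mg/kg, which is a limit and not a number, so the size of the step is only a floor. Compound 4 is the only value shown that is clear of the limit: the limit of > 50 mg/kg in this assay, at which 3 of the 4 values shown sit.

From the compounds shown here alone, whether fluorine, a methyl group or an amine at this place would keep the effect at small doses remains open. Also open, going by these compounds, is whether this change would give a similar step on another compound of the series.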